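The source may hold more compounds than are shown below. What is called first, only, known or untested is meant among the compounds shown, and "the series" means these compounds.

Working notes on the series. In a functional assay on A549 cells (Homo sapiens) for antiproliferative activity, read by MTT assay (on this read-out higher numbers stand for weaker inhibition and lower numbers for stronger inhibition), compound 1 `COc1cc2ncnc(NCc3cccc(NC(=O)Nc4ccccc4C)c3)c2cc1OC` gives 21400 nM. Compound 2 `COc1ccc(NC(=O)Nc2cccc(CNc3ncnc4cc(OC)c(OC)cc34)c2)cc1` differs from compound 1 only in carrying 4-methoxyphenyl in place of 2-methylphenyl on an amide-type nitrogen; in this assay compound 2 gives 24500 nM. Going by the values given here, compound 2 holds the highest of the two numbers so far, but the step of a 1.1-fold higher number from compound 1 to compound 2 (0.06 log units; within the scatter) lies within the scatter, so the two compounds cannot be told apart on these data.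

Compound 3 `COc1cc2ncnc(NCc3cccc(NC(=O)Nc4ccc(F)cc4)c3)c2cc1OC` is not yet measured. It differs from compound 2 by fluoro in place of methoxy on an aromatic carbon. Among the compounds with values here, the only step measured on this terminal ring, from 2-methylphenyl to 4-methoxyphenyl, stayed within the scatter, which is the sole piece of evidence bearing on a change at this position; a methoxy-to-fluoro exchange here has no precedent. On that basis no step beyond the scatter is expected in this assay for compound 3, in either direction, and the expected step is a 1.1-fold lower number from compound 2 to compound 3 (0.05 log units; within the scatter). Compound 3 is therefore estimated in this assay at 22000 nM, with a range from 8000 nM to 60000 nM; the range is wide because the change itself is unprecedented here and the surrounding numbers sit at the weak end of the read-out.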

Compound 3, half-maximal inhibitory concentration: 16900 nM
Beside the measured number, compound 3's estimate is 1.3-fold (0.11 log units) above it; low and high end bracket the measured number.
By their numbers in this assay, from the lowest: compounds 3, 1 and 2 (each within the scatter of the next).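

In this assay the terminal ring now has a second exchange, and the first made directly on the group para to a large group: fluoro in place of methoxy gives a step within the scatter (a 1.4-fold lower number from compound 2 to compound 3 (0.16 log units; within the scatter)), and 4-fluorophenyl in place of 2-methylphenyl likewise stays within it (a 1.3-fold lower number from compound 1 to compound 3 (0.10 log units; within the scatter)). Methoxy, with 2 heavy atoms and 1 hydrogen-bond acceptor, can thus give way to fluoro, with 1 heavy atom and 0 hydrogen-bond acceptors, without a step that can be told from the scatter, so 2-methylphenyl, 4-methoxyphenyl and 4-fluorophenyl cannot be separated on these data. Nothing available explains why these exchanges leave the number within the scatter.

From the compounds shown here alone, all three compounds carry a neutral, small group on this ring, so it remains open whether an amine, a carboxylic acid or a longer alkoxy chain at the same place would give a step beyond the scatter. Going by these compounds, it also remains open whether the same exchanges would stay within the scatter on a compound that differs elsewhere, for instance in the link joining the shared core to this ring.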